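Series notes: hydrogen in place of the silicon-bearing group

This account rests on a few compounds, and the source may have more. Where it says the series, first, only, none or still open, it means among the compounds named here.

Compound 1 `CC(C)CC1OCCC(Cl)=C1[Si](C)(C)C` gives 27000 nM in a functional assay on A2780 cells (Homo sapiens) for antiproliferative activity; a higher number here means a weaker inhibitor of growth, a lower number a stronger inhibitor of growth. Compound 2 `CC(C)CC1C=C(Cl)CCO1`, which carries a hydrogen atom in place of a group of 4 heavy atoms (3 carbon, 1 silicon; no ring), on a double-bonded ring carbon, reaches only the assay limit in this assay, > 100000 nM; the value sits at the limit of > 100000 nM in this assay, at which 1 of the 3 values shown sits. The step of an at least 3.7-fold higher number from compound 1 to compound 2 (0.56 log units; beyond the scatter) is therefore a lower bound on the loss.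

Compound 3 `C[C@H]1CC(Cl)=C([Si](C)(C)C)[C@@H](C2CCCCC2)O1` gives 17000 nM in this assay; compound 1 and compound 3 lie within the usual scatter of each other, so no order between them is claimed. The difference between the core of compound 1 and the core of compound 3 is not broken down here.

Compound 4 `C[C@H]1CC(Cl)=C[C@@H](C2CCCCC2)O1` differs from compound 3 by a hydrogen atom in place of a group of 4 heavy atoms (3 carbon, 1 silicon; no ring), on a double-bonded ring carbon. This is the same kind of change as from compound 1 to compound 2, but the surroundings differ: here the place is next to the ring atom that bears a cyclohexyl group and three ring bonds from the ring atom that bears a methyl group, whereas in compound 1 it is next to the ring atom that bears an isobutyl group. On the strength of an at least 3.7-fold higher number from compound 1 to compound 2 (0.56 log units; beyond the scatter), compound 4 is expected to lose activity by at least a comparable amount, an estimated step of a 4.7-fold higher number from compound 3 to compound 4 (0.67 log units; beyond the scatter). Compound 4 is thus estimated at 80000 nM in this assay, with an expected range from 35000 nM to 200000 nM, and a real chance that only the limit is reported.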

Compound 4, concentration for 50% growth inhibition: 19000 nM
The estimate for compound 4 lay 4.2-fold (0.62 log units) above the measured number; measured number below the stated range.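

In this assay, hydrogen in place of the silicon-bearing group on the core of compound 3 gives a 1.1-fold higher number from compound 3 to compound 4 (0.05 log units; within the scatter), so on this core the change costs nothing that can be told from the scatter. The change therefore does not carry over at one size between the two cores, and with compound 2 reported only as a limit, the gap is a lower bound: the same change on two cores in this assay, an at least 3.7-fold higher number (0.56 log units; beyond the scatter) from compound 1 to compound 2 and a 1.1-fold higher number (0.05 log units; within the scatter) from compound 3 to compound 4, at least 3.3-fold (0.52 log units) apart, beyond the scatter of two such steps

The cores of compound 1 and compound 3 differ in more than one place, so these two pairs do not show whether the isobutyl group, the cyclohexyl group or the methyl group sets the gap, and they give no rule for other cores in the series.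

Among the compounds shown here, open is how a core with only one of these groups exchanged would respond to the same change. Also open, on these data alone, is what a carbon group such as tert-butyl, or an amine, would give on the double-bonded ring carbon in place of the silicon-bearing group.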